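Notes on the step from compound 3 to compound 4

This account rests on a few compounds, and the source may have more. Where it says the series, first, only, none or still open, it means among the compounds named here.

Measured so far in a functional assay on HT-29 cells (Homo sapiens) for inhibition, read by MTT assay, with a stated time of 48 h (on this read-out higher numbers stand for weaker inhibition and lower numbers for stronger inhibition), on three compounds
- compound 1 `COc1ccc(-n2c(SCc3ccccc3)nnc2-c2cc(OC)c(OC)c(OC)c2)cc1` gives > 60000 nM as a limit
- compound 2 `COc1ccc(-n2c(SCc3ccc(C)cc3)nnc2-c2cc(OC)c(OC)c(OC)c2)cc1` gives > 60000 nM as a limit
- compound 3 `COc1ccc(-n2c(SCC(=O)c3ccc4ccccc4c3)nnc2-c2cc(OC)c(OC)c(OC)c2)cc1` gives 53400 nM as a number

For the measured compounds named here, compound 3 holds the only number so far, and the other two readings sit at one limit (the limit of > 60000 nM in this assay, at which 2 of the 3 values shown sit). Compound 4 `COc1ccc(-n2c(SCC(=O)C3CC3)nnc2-c2cc(OC)c(OC)c(OC)c2)cc1` has not been measured. The change is cyclopropyl in place of naphthalen-2-yl on a carbonyl carbon and it amounts to cyclopropyl in place of naphthalen-2-yl on a carbonyl carbon.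

The nearest measured steps are an at least 1.1-fold lower number from compound 1 to compound 3 (0.05 log units; that floor lies within the scatter) and an at least 1.1-fold lower number from compound 2 to compound 3 (0.05 log units; that floor lies within the scatter) and both bring in the (naphthalen-2-yl)carbonyl group. Each is only a floor, and each floor lies within the scatter. The remaining step, a step that the two limits leave unreadable from compound 1 to compound 2, gives no size. Going by the values given here, no measured step involves the cyclopropyl group, so the series offers no direct precedent for this change.

On those two floors, the expected step is a 1.1-fold higher number from compound 3 to compound 4 (0.05 log units; within the scatter) in this assay and no firm direction is expected beyond the scatter. Compound 4 is estimated at 60000 nM with an expected range from 25000 nM to 120000 nM and a reading as a limit alone is quite possible.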

Compound 4, half-maximal inhibitory concentration: > 60000 nM
Compound 4: no number, only a limit; the forecaster's own chance of this, stated with the estimate: 55%; the middle value lies on the limit itself.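

In this assay, cyclopropyl in place of naphthalen-2-yl on a carbonyl carbon gives an at least 1.1-fold higher number from compound 3 to compound 4 (0.05 log units; that floor lies within the scatter), so this first reading of a change at this position shows no shift beyond the scatter. Compound 4 gives > 60000 nM, which is a limit and not a number. The carbonyl on the saturated chain carbon bound to a sulfur therefore does not give a number when it carries cyclopropyl, and compound 3 remains the only compound in the series with a number; the steps from compound 1 and from compound 2 to compound 4 cannot be read, and most of the series now rests on a single limit: the limit of > 60000 nM in this assay, at which 3 of the 4 values shown sit.

On these data alone, it remains open whether any real difference separates naphthalen-2-yl from cyclopropyl on the carbonyl carbon, since the limit of compound 4 bounds that step on one side only. As far as these compounds go, it is also open how a phenyl, a tert-butyl or an amine on that carbonyl carbon would read, and whether any such group would give a number well clear of this limit.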